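Moving compound 3 away from its 2,6-dimethoxyphenyl group

The compounds below may be only part of what the source reports. "The series", "measured", "known", "first", "only" and "open" are said of these compounds alone.

Of the compounds shown here, three sharing one core have been measured in a functional assay on UACC-257 cells (Homo sapiens) for inhibition, read by sulforhodamine B assay, with a stated time of 48 h; on this read-out lower numbers stand for stronger inhibition of growth and higher numbers for weaker inhibition of growth. Compound 1 `O=C(Cc1csc2nc(-c3ccc(Br)cc3)cn12)N/N=C/c1ccccc1`, which carries a phenyl on the carbon with a double bond to nitrogen, gives 6170 nM. Compound 2 `O=C(Cc1csc2nc(-c3ccc(Br)cc3)cn12)N/N=C/c1ccc(O)cc1`, with a 4-hydroxyphenyl at that place, gives 1510 nM, which is a 4.1-fold lower number from compound 1 to compound 2 (0.61 log units; beyond the scatter). Compound 3 `COc1cccc(OC)c1/C=N/NC(=O)Cc1csc2nc(-c3ccc(Br)cc3)cn12`, with a 2,6-dimethoxyphenyl there, gives 24000 nM, the highest number of the three and so the weakest growth inhibition in this small set. The steps leading to it are a 3.9-fold higher number from compound 1 to compound 3 (0.59 log units; beyond the scatter) and a 16-fold higher number from compound 2 to compound 3 (1.20 log units; beyond the scatter), and both lie beyond the scatter.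

Compound 4 `O=C(Cc1csc2nc(-c3ccc(Br)cc3)cn12)N/N=C/c1ccc(Cl)cc1Cl` is the next to be read: 2,4-dichlorophenyl in place of 2,6-dimethoxyphenyl on a carbon with a double bond to nitrogen. In words, 2,4-dichlorophenyl stands in place of 2,6-dimethoxyphenyl on a carbon with a double bond to nitrogen. Within the data shown here, no measured compound carries this group, so no direct step exists for it. The nearest guide is compound 1, whose step a 3.9-fold higher number from compound 1 to compound 3 (0.59 log units; beyond the scatter) is here read in reverse, since it also concerns the loss of the 2,6-dimethoxyphenyl group. A modest fall in the number is therefore expected, towards stronger inhibition. The estimated change is a 4.8-fold lower number from compound 3 to compound 4 (0.68 log units; beyond the scatter). For compound 4 the estimated value is 5000 nM, with an expected range of 1500 nM to 16000 nM.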

Compound 4, concentration for 50% growth inhibition: 69200 nM
For compound 4 the middle estimate is 14-fold (1.14 log units) below the measured one; the whole stated range lies below it.
By their numbers in this assay, from the lowest: compound 2; then compound 1; then compound 3; then compound 4.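

In this assay, giving up the 2,6-dimethoxyphenyl group did not by itself restore growth inhibition: the 2,4-dichlorophenyl group moved the read-out the other way (a 2.9-fold higher number from compound 3 to compound 4 (0.46 log units; beyond the scatter)). Compound 4 therefore marks the weakest end of the series, well beyond both the unsubstituted phenyl (an 11-fold higher number from compound 1 to compound 4 (1.05 log units; beyond the scatter)) and the 4-hydroxyphenyl (a 46-fold higher number from compound 2 to compound 4 (1.66 log units; beyond the scatter)), so this position spans a wider range than the first three compounds showed. Among the four, only the 4-hydroxyphenyl of compound 2 gives a lower number than the phenyl of compound 1, while the two rings carrying a pair of groups, in compound 3 and compound 4, both give higher numbers, and nothing in the available data gives a reason for these differences.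

The compounds shown leave open whether a single chlorine or a single methoxy group on the phenyl would already raise the number, or whether only the pairs do. They also leave open whether an amine or a carboxylic acid on that phenyl would follow the 4-hydroxyphenyl of compound 2 towards stronger growth inhibition.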